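From trifluoromethyl to methyl on a shared core

The source may hold more compounds than are shown below. What is called first, only, known or untested is meant among the compounds shown, and "the series" means these compounds.

Measured in an ADME assay on MDCK cells (Canis lupus familiaris) for cytotoxicity, read by MTT assay, with a stated time of 24 h; on this read-out lower numbers stand for higher toxicity in this test and higher numbers for lower toxicity in this test:
Compound 1 `N#Cc1ccc(S(=O)(=O)NCc2cc3ccccc3s2)cc1`: "not determined" (no result reported)
Compound 2 `O=S(=O)(NCc1cc2ccccc2s1)c1ccc(Cl)cc1`: "not determined" (no result reported)
Compound 3 `O=S(=O)(NCc1cc2ccccc2s1)c1ccc(C(F)(F)F)cc1`: > 179000 nM

Only compound 3 has a reported result in this assay, and its > 179000 nM is a limit of the assay, not a number. The series therefore stands at the limit of > 179000 nM in this assay, at which 1 of the 3 values shown sits. For the measured compounds named here, no result was reported for the other two compounds, so no measured step between compounds is available as a guide.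

Compound 4 `Cc1ccc(S(=O)(=O)NCc2cc3ccccc3s2)cc1` has not yet been measured. It carries methyl in place of trifluoromethyl on an aromatic carbon, para to a large group: methyl in place of trifluoromethyl on an aromatic carbon.

With so little to go on, no change beyond the usual scatter is expected in this assay, and no direction can be favoured. The expectation rests on compound 3 alone, whose > 179000 nM is a limit. The estimated step is a step that the limit leaves unreadable from compound 3 to compound 4, and a report of only a limit would not be surprising. For compound 4 the estimated value is 200000 nM, with an expected range from 90000 nM to 350000 nM.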

Compound 4, half-maximal cytotoxic concentration: > 210000 nM
Compound 4: no number, only a limit; the forecaster's own chance of this, stated with the estimate: 65%; middle value at least 1.0-fold (0.02 log units) away from the limit.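

In this assay compound 4 gives > 210000 nM as a limit of the assay, not a number. Compound 3 gives > 179000 nM as a limit too. For the compounds shown here, no step between compound 3 and compound 4 can be read from these two limits. The compounds shown leave open where either value truly lies, and whether methyl in place of trifluoromethyl changes the read-out at all.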